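Swapping Chloro for Methoxy on a Desaturase Inhibitor

This account rests on a few compounds, and the source may have more. Where it says the series, first, only, none or still open, it means among the compounds named here.

Of the compounds shown here, three have been measured in an assay for inhibition of acyl-CoA (8-3)-desaturase (Homo sapiens); a lower number here means a stronger inhibitor, a higher number a weaker inhibitor. Compound 1 `Clc1cccc(Nc2ncnc3ccsc23)c1` gives 50 nM, and compound 2 `Fc1cccc(Nc2n[nH]c3ccccc23)c1` gives 59 nM. Compound 3 `Clc1cccc(Nc2n[nH]c3ccc(Cl)cc23)c1` gives 5 nM, the lowest of the three numbers, with compound 1 nearest and compound 2 furthest, both beyond the scatter. No two of these compounds differ in only one place, so no single change has been sized on its own.

Compound 4 `COc1ccc2[nH]nc(Nc3cccc(Cl)c3)c2c1` differs from compound 3 in one place: methoxy in place of chloro on an aromatic carbon. Nothing measured here shows what such a swap does in this assay , so the direction is open. The estimate for compound 4 is 15 nM, within 4 nM to 60 nM, a step of a 3.0-fold higher number from compound 3 to compound 4 (0.48 log units; beyond the scatter) expected to be modest.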

Compound 4, half-maximal inhibitory concentration: 8 nM
Beside the measured number, compound 4's estimate is 1.9-fold (0.27 log units) above it; low and high end bracket the measured number.
By their numbers in this assay, from the lowest: compounds 3 and 4 (each within the scatter of the next); then compounds 1 and 2 (each within the scatter of the next).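

Going by these compounds alone, the only single change sized so far in this assay is methoxy in place of chloro on this aromatic carbon, and it gives a 1.6-fold higher number from compound 3 to compound 4 (0.20 log units; within the scatter), so the two groups cannot be told apart here. The position therefore takes two heavy atoms, one of them a hydrogen-bond acceptor, in place of a lone chlorine with no measurable loss. No measured property offers a reason for this match. Still open, going by these compounds, is how an amine, a carboxylic acid or a longer chain would fare at this position. One swap also cannot show how far this holds for other groups.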